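The source may report more compounds than this note shows. Statements on the series, on what has been measured and on what is new or still open speak of the compounds shown alone.

Working notes on the series. Compound 1 `CCc1ccc(C(=O)NCCCN2CCN(CCCNc3ccnc4cc(Cl)ccc34)CC2)cc1` gives 3900 nM in an ADME assay on L6 cells (Rattus norvegicus) for cytotoxicity (on this read-out lower numbers stand for stronger inhibition and higher numbers for weaker inhibition), the lower of the two numbers in hand. Compound 2 `CC(C)=CC(=O)NCCCN1CCN(CCCNc2ccnc3cc(Cl)ccc23)CC1` gives 30000 nM in this assay. Within the data shown here, the one measured step, a 7.7-fold higher number from compound 1 to compound 2 (0.89 log units; beyond the scatter), swaps the aryl group for a branched alkenyl chain at the same amide position. Compound 3 `CCCC(=O)NCCCN1CCN(CCCNc2ccnc3cc(Cl)ccc23)CC1` carries a related change: propyl in place of 4-ethylphenyl on a carbonyl carbon. The earlier step bears on it directly, and a rise of comparable size in this assay is expected, so compound 3 is estimated at 20000 nM, within 7000 nM to 60000 nM. That estimate means a step of a 5.1-fold higher number from compound 1 to compound 3 (0.71 log units; beyond the scatter).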

Compound 3, half-maximal inhibitory concentration: 84700 nM
Beside the measured number, compound 3's estimate is 4.2-fold (0.63 log units) below it; the whole stated range lies below it.
By their numbers in this assay, from the lowest: compound 1; then compound 2; then compound 3.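

With propyl on the carbonyl carbon, the step is a 22-fold higher number from compound 1 to compound 3 (1.34 log units; beyond the scatter) in this assay, so a second group without a ring also gives a far higher number than the 4-ethylphenyl amide. The two groups without a ring do not read alike, with a 2.8-fold higher number from compound 2 to compound 3 (0.45 log units; beyond the scatter). Nothing at hand explains either rise.

The compounds shown leave open whether the lower number of compound 1 follows the aromatic ring itself or the ethyl on it. A plain phenyl or a cyclohexyl on the same carbonyl carbon would separate these readings.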